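This account rests on a few compounds, and the source may have more. Where it says the series, first, only, none or still open, it means among the compounds named here.

Compound 1 `CN(C)c1ncnc2c1ncn2COCCO` is the starting point, and its cytotoxicity is read in an ADME assay on L1210/0 cells (Mus musculus) for cytotoxicity, with a stated time of 48 h; a lower number here means a stronger inhibitor, a higher number a weaker inhibitor. In this assay compound 1 gives only a limit, > 200000 nM. Compound 2 `CN(C)c1nc2c(=O)[nH]c(N)nc2n1COCCO` has a different core, and the difference between the two cores is not broken down here. In this assay compound 2 likewise stops at a limit, > 200000 nM. Compound 3 `Nc1nc2c(nc(O)n2COCCO)c(=O)[nH]1` differs from compound 2 by hydroxy in place of dimethylamino on an aromatic carbon. In this assay compound 3 also sits at a limit, > 200000 nM. The step that the two limits leave unreadable from compound 2 to compound 3 therefore cannot be read, because of the limit of > 200000 nM in this assay, at which 3 of the 3 values shown sit. Compound 4 `OCCOCn1cnc2c(O)ncnc21`, not yet measured, differs from compound 1 by hydroxy in place of dimethylamino on an aromatic carbon. It is the same kind of change as that from compound 2 to compound 3, but the place differs: here it is a six-membered aromatic ring with 2 nitrogen, next to the ring nitrogen, ortho to a fused ring, meta to a fused ring and opposite the ring nitrogen, rather than a five-membered aromatic ring, between two ring nitrogen atoms, next to the ring atom that bears a (2-hydroxyethoxy)methyl group. Compound 4 is expected to give about 200000 nM, most probably again only a limit, within 100000 nM to 400000 nM. The step this implies, a number no higher from compound 1 to compound 4 (the limit leaves the size open), is expected to be small, because of the limit of > 200000 nM in this assay, at which 3 of the 3 values shown sit.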

Compound 4, half-maximal inhibitory concentration: > 200000 nM
Compound 4: only a limit was reported (the forecaster's own chance of this, stated with the estimate: 85%); the middle value sits exactly at the limit.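

In this assay compound 4 gives only a limit, > 200000 nM. No step can be read between compound 1 and compound 4, because the comparison rests on limits alone: the limit of > 200000 nM in this assay, at which 4 of the 4 values shown sit. The compounds shown leave open whether hydroxy in place of dimethylamino changes cytotoxicity at all, and where the true values of these four compounds lie.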